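This account rests on a few compounds, and the source may have more. Where it says the series, first, only, none or still open, it means among the compounds named here.

In a functional assay on HEL cells (Homo sapiens) (on this read-out lower numbers stand for higher toxicity in this test and higher numbers for lower toxicity in this test), compound 1 `COC(=O)CC(=O)NC1=CS(=O)(=O)O[C@@]12[C@@H](CO[Si](C)(C)C(C)(C)C)O[C@@H](n1cc(C)c(=O)n(C)c1=O)[C@@H]2O[Si](C)(C)C(C)(C)C` gives 29000 nM. Compound 2 `COC(=O)C(=O)CNC1=CS(=O)(=O)O[C@@]12[C@@H](CO[Si](C)(C)C(C)(C)C)O[C@@H](n1cc(C)c(=O)n(C)c1=O)[C@@H]2O[Si](C)(C)C(C)(C)C` reads > 200000 nM, which is a limit and not a number, as shown by the limit of > 200000 nM in this assay, at which 1 of the 2 values shown sits. Compound 3 `CCNC(=O)NC1=CS(=O)(=O)O[C@@]12[C@@H](CO[Si](C)(C)C(C)(C)C)O[C@@H](n1cc(C)c(=O)n(C)c1=O)[C@@H]2O[Si](C)(C)C(C)(C)C` differs from compound 2 by ethylcarbamoyl in place of ((methoxycarbonyl)carbonyl)methyl on an amine nitrogen, with ethylcarbamoyl in place of ((methoxycarbonyl)carbonyl)methyl on an amine nitrogen. Among the measured compounds shown here, the one measured step on this nitrogen is an at least 6.8-fold higher number from compound 1 to compound 2 (0.83 log units; beyond the scatter). A move to lower numbers in this assay is expected, since ethylcarbamoyl is closer to the ((methoxycarbonyl)methyl)carbonyl of compound 1 at 29000 nM. The expected size is an at least 3.3-fold lower number from compound 2 to compound 3 (0.52 log units; beyond the scatter). Compound 3 is estimated at 60000 nM, within an expected range of 20000 nM to 180000 nM.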

Compound 3, half-maximal cytotoxic concentration: 10000 nM
Compound 3: middle estimate off by 6.0-fold (0.78 log units), on the high side, and the stated range ends above it.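

On this amine nitrogen in this assay, ethylcarbamoyl gives the lowest reading of the three groups, with an at least 20-fold lower number from compound 2 to compound 3 (1.30 log units; beyond the scatter) and a 2.9-fold lower number from compound 1 to compound 3 (0.46 log units; beyond the scatter). Compound 1 and compound 3 both carry a carbonyl directly on the nitrogen and give the two numerical readings, so the group on this nitrogen can move the reading in either direction. Compound 2 stands only as a limit: the limit of > 200000 nM in this assay, at which 1 of the 3 values shown sits.

Going by these compounds, whether the carbonyl on the nitrogen or the rest of the group sets the reading stays open. On these data alone, how acetyl, a longer chain such as propylcarbamoyl, or a group ending in a carboxylic acid would read on this nitrogen also remains open.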